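The source may report more compounds than this note shows. Statements on the series, on what has been measured and on what is new or still open speak of the compounds shown alone.

Measured compounds:
Compound 1, `N#Cc1ccc(O[C@H]2CN(S(=O)(=O)c3ccc(Cl)cc3Cl)C[C@@H]2O)cc1`, gives 32 nM in an assay on cells for antagonist activity at transient receptor potential cation channel subfamily V member 4 (Homo sapiens), read by FLIPR and calcium flux, with a stated time of 10 min; a lower number here means a stronger inhibitor, a higher number a weaker inhibitor.
Compound 2, `N#Cc1ccc(S(=O)(=O)[C@H]2CN(S(=O)(=O)c3ccc(Cl)cc3Cl)C[C@@H]2O)cc1`, gives 25 nM in this assay.
Compound 3, `N#Cc1ccc(S(=O)(=O)[C@H]2CN(S(=O)(=O)c3ccc(Cl)cc3Cl)C[C@@]2(O)CO)cc1`, gives 7.9 nM in this assay.

Among these three, compound 3 has the lowest number. Compound 2 is the nearest to it and compound 1 the furthest, and both of those gaps are beyond the usual scatter of repeated measurements, so compound 3 is the strongest inhibitor of the three in this assay.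

The next compound, compound 4, `N#Cc1ccc(S(=O)(=O)[C@@H]2CN(S(=O)(=O)c3ccc(Cl)cc3Cl)C[C@@]2(O)CO)cc1`, keeps every atom and bond of compound 3. For the measured compounds named here, the only change is this: the two compounds have the same atoms and bonds and differ only in configuration as drawn: 1 of 2 stereo elements differ; a stereocentre at a saturated ring carbon is drawn S in compound 3 and R in compound 4. Going by the values given here, no measured pair here differs only in configuration, so there is no comparable step to lean on. All three measured compounds share the configuration drawn in compound 3 at that ring carbon, so the effect of turning it over is simply untested. A change of configuration at a single ring carbon can leave potency untouched, or it can cost a good deal; with nothing measured to anchor it, the expectation here is a step toward a higher number, estimated as a 7.6-fold higher number from compound 3 to compound 4 (0.88 log units; beyond the scatter). On that basis compound 4 is expected to give about 60 nM in this assay, with a plausible range from 15 nM to 300 nM.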

Compound 4, half-maximal inhibitory concentration: 1590 nM
Estimate against measurement, compound 4: 27-fold (1.42 log units) below, and the stated range ends below it.
By their numbers in this assay, from the lowest: compound 3; then compounds 2 and 1 (each within the scatter of the next); then compound 4.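

Turning over a single stereocentre at a saturated ring carbon, drawn S in one compound and R in the other, gives a 200-fold higher number from compound 3 to compound 4 (2.30 log units; beyond the scatter) in this assay, a large step toward weaker inhibition. The earlier compounds shown here all share one configuration at this carbon, and so they could show only what the other parts of the structure do, never that inhibition hangs so heavily on how this one carbon is drawn. The whole step can be assigned to that single stereocentre, because no atom or bond changes: the fact that compounds 3 and 4 differ only in the configuration as drawn.

Still open, as far as these compounds go, is whether turning over this carbon costs as much in compound 1 or compound 2, and what turning over the other stereocentre would do, alone or together with this one. Also open, from the compounds shown here alone, is how the more active configuration of compound 3 would respond if its hydroxymethyl group gave way to an amine, a carboxylic acid or a longer chain.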